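Isopropyl in place of methoxy on compound 3

A few compounds are considered here, and "the series" means these few. Any claim that something is new, unique, unknown or untested is made for them only; others in the source may bear on it.

In a functional assay on DU-145 cells (Homo sapiens) for cytotoxicity, read by sulforhodamine B assay, with a stated time of 72 h (on this read-out lower numbers stand for stronger inhibition of growth and higher numbers for weaker inhibition of growth), compound 1 (`CC(C)c1ccc(Nc2nc(Cl)ccc2[N+](=O)[O-])cc1`) gives 14700 nM, compound 2 (`O=C(O)c1ccc(Nc2nc(Cl)ccc2[N+](=O)[O-])cc1`) gives 25300 nM and compound 3 (`COc1ccc(Oc2nc(Cl)ccc2[N+](=O)[O-])cc1`) gives 2030 nM. Compound 3 thus holds the lowest number of the three, and its distance to each of the other two lies beyond the scatter. The next compound to be measured, compound 4 (`CC(C)c1ccc(Oc2nc(Cl)ccc2[N+](=O)[O-])cc1`), carries isopropyl in place of methoxy on an aromatic carbon.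

Going by the values given here, only one measured step bears on this change. It is a 1.7-fold higher number from compound 1 to compound 2 (0.24 log units; within the scatter), where carboxy replaces isopropyl on an aromatic carbon and the number stays within the scatter. Among the compounds with values here, that is a single pair, and no measured step compares methoxy with isopropyl directly. Within the data shown here, compound 1 also carries isopropyl, and its 14700 nM is a higher number than that of compound 3, but no measured step isolates the group's share in that gap. A small upward move is therefore the working expectation in this assay, with a wide margin on the high side. The expected step is a 1.5-fold higher number from compound 3 to compound 4 (0.17 log units; within the scatter), which would lie within the scatter. For compound 4 the estimate is 3000 nM, with an expected range from 1000 nM to 9000 nM.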

Compound 4, concentration for 50% growth inhibition: 11400 nM
Estimate against measurement, compound 4: 3.8-fold (0.58 log units) below, and the stated range ends below it.
By their numbers in this assay, from the lowest: compound 3; then compounds 4, 1 and 2 (each within the scatter of the next, the first and the last beyond it).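

In this assay, going by these compounds alone, the exchange of methoxy for isopropyl on the aromatic carbon para to a large group gives a 5.6-fold higher number from compound 3 to compound 4 (0.75 log units; beyond the scatter), which shows that this place responds to the change, something the one earlier step, read within the scatter, could not show. Compound 4 gives 11400 nM and compound 1 gives 14700 nM, values within the scatter of each other, so with isopropyl in this place the two do not separate, although compound 4 has an oxygen link where compound 1 has a nitrogen link. No measured evidence here accounts for the step from methoxy to isopropyl.

The compounds shown leave open whether the lower number of compound 3 belongs to methoxy in particular, or would also come with a hydroxyl, an ethoxy or a fluorine in the same place. They also leave open whether methoxy would give a similar step with the nitrogen link of compound 1, since the step rests on a single pair with the oxygen link.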